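The compounds below may be only part of what the source reports. "The series", "measured", "known", "first", "only" and "open" are said of these compounds alone.

Measured in a functional assay with Oryctolagus cuniculus as the target; on this read-out lower numbers stand for stronger inhibition and higher numbers for weaker inhibition:
- Compound 1 `CNC(=N)Nc1nc(-c2ccc(OC)cc2)c(-c2ccc(OC)cc2)s1`: 62 nM
- Compound 2 `COc1ccc(-c2nc(/N=C(\N)N(C)C)sc2-c2ccc(OC)cc2)cc1`: 37 nM
- Compound 3 `COc1ccc(-c2nc(CN)sc2-c2ccc(OC)cc2)cc1`: > 100 nM

Compound 3 has no exact number in this assay. Its entry of > 100 nM is a limit of the assay.

Compound 4 `CCN(CC)C(=O)c1nc(-c2ccc(OC)cc2)c(-c2ccc(OC)cc2)s1` keeps the core of compound 3 and carries diethylcarbamoyl in place of aminomethyl on an aromatic carbon.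

For the measured compounds named here, two measured steps bear on this position, both ending at the aminomethyl group. The first is an at least 1.6-fold higher number from compound 1 to compound 3 (0.20 log units; that floor lies within the scatter). The second is an at least 2.7-fold higher number from compound 2 to compound 3 (0.43 log units; beyond the scatter). Neither involves diethylcarbamoyl, so they serve only as a loose guide. The step of a 1.7-fold lower number from compound 1 to compound 2 (0.22 log units; within the scatter) shows that the groups of compound 1 and compound 2 can be exchanged without a change beyond the scatter.

Going by compound 2 at 37 nM, replacing aminomethyl can bring a lower number, but the entering group here is of another kind. No step beyond the scatter is therefore expected, only a slight move towards a lower number, and the estimated step is an at least 1.1-fold lower number from compound 3 to compound 4 (0.04 log units; that floor lies within the scatter). For compound 4 the expected value is 90 nM, with an estimated range from 25 nM to 300 nM.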

Compound 4, half-maximal inhibitory concentration: < 10 nM
Compound 4 gave a limit, no number; the forecaster's own chance of this, stated with the estimate: 40%; middle value at least 9.0-fold (0.95 log units) away from the limit.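

In this assay, the entry for compound 4 is a limit, < 10 nM, so the steps that end at it give only a floor for their size: the limit of < 10 nM in this assay, at which 1 of the 4 values shown sits.

Replacing aminomethyl with diethylcarbamoyl at this position gives an at least 10-fold lower number from compound 3 to compound 4 (1.00 log units; beyond the scatter), and the floor on that step also rests on a limit at the other end: the limit of > 100 nM in this assay, at which 1 of the 4 values shown sits.

For the compounds shown here, the same group also stands clear of the two larger nitrogen-rich groups, with an at least 3.7-fold lower number from compound 2 to compound 4 (0.56 log units; beyond the scatter) and an at least 6.2-fold lower number from compound 1 to compound 4 (0.79 log units; beyond the scatter), so the earlier compounds, among which only the step to aminomethyl passed the scatter, did not show that a group with 0 hydrogen-bond donors can sit here and give the lowest number of the four.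

The compounds shown do not separate the share of the carbonyl from that of the two ethyl chains, so it remains open whether a dimethylamide, a pyrrolidine amide, an ethyl ester or a carboxylic acid at this position would give a similar result. On these data alone, how far the number of compound 4 lies past its limit also remains open.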